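Compound 4 and its expected deacetylase inhibition

The compounds below may be only part of what the source reports. "The series", "measured", "known", "first", "only" and "open" are said of these compounds alone.

Of the compounds shown here, three built on one shared core have been tested in an assay on isolated protein for inhibition of protein deacetylase HDAC6 (Homo sapiens); a higher number here means a weaker inhibitor, a lower number a stronger inhibitor. Compound 1 `O=C(c1ccc(-c2nc(-c3cccnc3)no2)s1)C(F)(F)F` gives 840 nM, the highest of the three numbers, though its steps to the other two stay within the scatter. Compound 2 `O=C(c1ccc(-c2nc(-c3ccc(F)cc3F)no2)s1)C(F)(F)F` gives 580 nM and compound 3 `O=C(c1ccc(-c2nc(-c3ccccn3)no2)s1)C(F)(F)F` gives 500 nM. Compound 4 `Cc1cccc(-c2noc(-c3ccc(C(=O)C(F)(F)F)s3)n2)c1` is not yet measured and differs from compound 1 by 3-methylphenyl in place of pyridin-3-yl on an aromatic carbon. The nearest comparison is a 1.4-fold lower number from compound 1 to compound 2 (0.16 log units; within the scatter), which likewise replaced pyridin-3-yl with a ring of carbon only, and a 1.7-fold lower number from compound 1 to compound 3 (0.23 log units; within the scatter) was equally small. No step beyond the scatter is therefore expected here. Compound 4 is estimated at 650 nM, with a range from 280 nM to 1500 nM. That estimate amounts to an expected step of a 1.3-fold lower number from compound 1 to compound 4 (0.11 log units; within the scatter).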

Compound 4, half-maximal inhibitory concentration: 680 nM
The estimate for compound 4 lay 1.0-fold (0.02 log units) below the measured number; low and high end bracket the measured number.
By their numbers in this assay, from the lowest: compounds 3, 2, 4 and 1 (each within the scatter of the next).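

Placing 3-methylphenyl at this position adds a methyl group to a ring of carbon only, and this assay shows a 1.2-fold lower number from compound 1 to compound 4 (0.09 log units; within the scatter) for this change. Against the other rings the result is a 1.4-fold higher number from compound 3 to compound 4 (0.13 log units; within the scatter) and a 1.2-fold higher number from compound 2 to compound 4 (0.07 log units; within the scatter) so these four rings, with a ring nitrogen, fluorine or methyl, all lie within the scatter of one another.

Nothing available here accounts for this flat picture. As far as these compounds go, it remains open whether an amine or a carboxylic acid on this ring, or a longer chain in its place, would move the number beyond the scatter.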